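The source may hold more compounds than are shown below. What is called first, only, known or untested is meant among the compounds shown, and "the series" means these compounds.

Values in a functional assay, with a stated time of 30 min, in the absence of a further agent; on this read-out higher numbers stand for weaker inhibition and lower numbers for stronger inhibition:
- compound 1 `O=C(Nc1nnc(-c2ccc(O)c(O)c2)s1)C1CCCCC1`: 37300 nM
- compound 2 `CC(=O)Nc1nnc(-c2ccc(O)c(O)c2)s1`: 23400 nM
- compound 3 `O=C(Nc1nnc(-c2ccc(O)c(O)c2)s1)c1ccccc1`: not yet measured

Going by the values given here, compound 2 and compound 1 lie within the scatter of each other in this assay, so compound 2 stands level with the only other measured compound. The change to compound 3 is phenyl in place of methyl on a carbonyl carbon. Among the compounds with values here, one measured step bears on this carbonyl carbon: a 1.6-fold lower number from compound 1 to compound 2 (0.20 log units; within the scatter), with methyl in place of cyclohexyl. On that evidence, no change beyond the scatter is expected in this assay. The expected step is a 1.2-fold higher number from compound 2 to compound 3 (0.06 log units; within the scatter). For compound 3 the estimated value is 27000 nM, with an expected range of 13000 nM to 56000 nM.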

Compound 3, half-maximal inhibitory concentration: 23400 nM
Compound 3: the middle estimate sits 1.2-fold (0.06 log units) above what was measured; the range from low to high includes it.
By their numbers in this assay, from the lowest: compounds 2, 3 and 1 (each within the scatter of the next).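

In this assay, the aromatic phenyl on this carbonyl carbon reads the same as the non-aromatic groups, with no change at the digits printed from compound 2 to compound 3 (within the scatter) and a 1.6-fold lower number from compound 1 to compound 3 (0.20 log units; within the scatter). Methyl, cyclohexyl and phenyl thus all lie within the scatter of each other, so an aromatic ring here does not separate compound 3 from compound 1 or compound 2. No measurement at hand explains this flat picture. Going by these compounds, whether an amine, a carboxylic acid or a longer chain at this carbonyl carbon would move the number beyond the scatter remains open. On these data alone, the effect of changes elsewhere on the shared core also remains open.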